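The source may report more compounds than this note shows. Statements on the series, on what has been measured and on what is new or still open speak of the compounds shown alone.

Working notes on the series. Compound 3 `CCCCOC(=O)NS(=O)(=O)c1ccc(CCC)cc1-c1ccc(Cn2c(CC)nc3ccccc32)cc1` stands lowest of the three measured compounds in an assay on membranes from HEK293 cells for displacement of a labelled ligand from Type-2 angiotensin II receptor (Homo sapiens), read by radioligand binding; a higher number here means a weaker inhibitor, a lower number a stronger inhibitor: compound 3 gives 11 nM. Its nearest neighbour is compound 2 `CCCCOC(=O)NS(=O)(=O)c1ccc(CCC)cc1-c1ccc(Cn2cnc3ccccc32)cc1`, which in this assay gives 29 nM, and the furthest is compound 1 `CCCCOC(=O)NS(=O)(=O)c1ccc(CCC)cc1-c1ccc(Cn2c(-c3ccccc3)nc3ccccc32)cc1`, which in this assay gives 590 nM. The steps that led here are a 20-fold lower number from compound 1 to compound 2 (1.31 log units; beyond the scatter) and a 54-fold lower number from compound 1 to compound 3 (1.73 log units; beyond the scatter), both large, and the smaller 2.6-fold lower number from compound 2 to compound 3 (0.42 log units; beyond the scatter).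

Compound 4 `CCCCOC(=O)NS(=O)(=O)c1ccc(CCC)cc1-c1ccc(Cn2c(C(F)(F)F)nc3ccccc32)cc1` is not yet measured. The change from compound 3 is trifluoromethyl in place of ethyl on an aromatic carbon. Going by the values given here, no measured step swaps one small group for another at this carbon; the only step of comparable scope is a 2.6-fold lower number from compound 2 to compound 3 (0.42 log units; beyond the scatter), which shows that a small group here can move the number modestly, while a 20-fold lower number from compound 1 to compound 2 (1.31 log units; beyond the scatter) shows a much larger effect for a bulkier group. Compound 4 is therefore expected to sit close to compound 3, with a 1.4-fold higher number from compound 3 to compound 4 (0.13 log units; within the scatter) as the expected step, within or only modestly beyond the scatter. The estimate for compound 4 in this assay is 15 nM, with a range from 5 nM to 60 nM.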

Compound 4, inhibition constant: 13 nM
The estimate for compound 4 lay 1.2-fold (0.06 log units) above the measured number; low and high end bracket the measured number.
By their numbers in this assay, from the lowest: compounds 3 and 4 (each within the scatter of the next); then compound 2; then compound 1.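

In this assay, replacing one group with another at this carbon, rather than with hydrogen or phenyl, gives a 1.2-fold higher number from compound 3 to compound 4 (0.07 log units; within the scatter), so trifluoromethyl and ethyl cannot be told apart here, although the entering group has 4 heavy atoms and the leaving group 2. Trifluoromethyl also keeps the distance from the other two compounds, with a 2.2-fold lower number from compound 2 to compound 4 (0.35 log units; beyond the scatter) and a 45-fold lower number from compound 1 to compound 4 (1.66 log units; beyond the scatter), so among the compounds shown, two different groups without a ring both give lower numbers than hydrogen, while phenyl goes against this with the highest number. No measurement available here bears on why ethyl and trifluoromethyl read alike.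

Still open, from the compounds shown here alone, is whether a longer chain such as butyl, an amine or a carboxylic acid on this carbon would stay near compound 3 and compound 4 or move toward compound 1.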